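Taking the Chloro Group off Compound 2

A few compounds are considered here, and "the series" means these few. Any claim that something is new, unique, unknown or untested is made for them only; others in the source may bear on it.

In a functional assay on Hs-578T cells (Homo sapiens) for inhibition, read by sulforhodamine B assay, with a stated time of 48 h, tested at 10 uM (on this read-out higher numbers stand for more inhibition of growth at the one concentration tested and lower numbers for less inhibition of growth), compound 1 `COc1ccc(-c2nc3sc(-c4ccccc4)cn3n2)cc1` gives 40%. Compound 2 `Clc1ccc(-c2cn3nc(-c4ccccc4)nc3s2)cc1` gives 40%, level with compound 1 within the scatter. Compound 3 `c1ccc(-c2nc3sc(-c4ccccc4)cn3n2)cc1` has not yet been measured. It carries hydrogen in place of chloro on an aromatic carbon, para to a large group: hydrogen in place of chloro on an aromatic carbon. For the measured compounds named here, no measured pair of compounds differs in only one place, so the data offer no direct guide to this change. The expected step in this assay, a number 5 percentage points lower from compound 2 to compound 3 (within the scatter), is small and stays within the scatter. For compound 3, the estimated value is 35%, with an expected range of 15% to 55%.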

Compound 3, percent growth inhibition at one concentration: 9%
Compound 3: the middle estimate sits 26 percentage points above what was measured; measured number below the stated range.
By their numbers in this assay, from the lowest: compound 3; then compounds 1 and 2 (each within the scatter of the next).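

In this assay, the chloro group turns out to matter: hydrogen in its place gives a number 31 percentage points lower from compound 2 to compound 3 (beyond the scatter). Hydrogen in place of methoxy gives a number 31 percentage points lower from compound 1 to compound 3 (beyond the scatter), so the unsubstituted compound 3 falls clearly behind both substituted compounds, which the level pair alone could not show. No data here explain this loss. Open, on these data alone, is whether other groups at this place, such as fluoro, an amine or a carboxylic acid, would hold the inhibition or raise it.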